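The source may report more compounds than this note shows. Statements on the series, on what has been measured and on what is new or still open speak of the compounds shown alone.

In a functional assay on HCT-15 cells (Homo sapiens) for antiproliferative activity, read by sulforhodamine B assay (on this read-out higher numbers stand for weaker inhibition of growth and lower numbers for stronger inhibition of growth), compound 1 `COc1cccc(OCCC(C)(C)C)c1C(=O)/C=C/c1ccc(O)cc1` gives no number, only a limit of the assay (> 30000 nM). Compound 2 `O=C(/C=C/c1ccc(O)cc1)c1c(O)cccc1OCC1CCCCC1` is also a limit (> 30000 nM). By contrast, compound 3 `CC(C)(C)CCOc1cccc(O)c1C(=O)/C=C/c1ccc(S(N)(=O)=O)cc1` gives a true number (2930 nM).

Compound 4 `O=C(/C=C/c1ccc(O)cc1)c1c(O)cccc1OCCC1CCCC1` has the same atoms as compound 2, joined differently (cyclopentylmethyl in place of cyclohexyl on a saturated chain carbon bound to an oxygen on an aromatic ring), with cyclopentylmethyl in place of cyclohexyl on a saturated chain carbon bound to an oxygen on an aromatic ring. Going by the values given here, no measured pair shows what this change does. The expectation therefore rests on compound 2 (> 30000 nM), with no shift beyond the usual scatter in either direction. The expected step (an at least 1.2-fold lower number from compound 2 to compound 4 (0.07 log units; that floor lies within the scatter)) is correspondingly small. For compound 4 the estimate is 25000 nM (expected range 10000 nM to 40000 nM), and another limit would be no surprise.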

Compound 4, concentration for 50% growth inhibition: 3310 nM
Compound 4: middle estimate off by 7.6-fold (0.88 log units), on the high side; the whole stated range lies above it.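

Moving from cyclohexylmethyl to 2-cyclopentylethyl on the same core, with the atom count unchanged, gives an at least 9.0-fold lower number from compound 2 to compound 4 (0.95 log units; beyond the scatter) in this assay. Going by these compounds alone, this position therefore responds to how the side-chain carbons are arranged, not only to how many there are, which no earlier compound could show. The true step may be larger, as compound 2 gives only a limit: the limit of > 30000 nM in this assay, at which 2 of the 4 values shown sit.

The compounds shown do not separate the effect of the five-membered ring from that of the longer link to the oxygen. On these data alone, how a 2-cyclohexylethyl chain, or an amine at the chain end, would behave also remains open.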